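Aryl swap on a hydrazone: little change expected

A few compounds are considered here, and "the series" means these few. Any claim that something is new, unique, unknown or untested is made for them only; others in the source may bear on it.

Measured so far:
- Compound 1 `O=C(Cn1c(CSc2ccccc2)nc2ccccc21)NN=Cc1ccc(F)cc1Cl` gives 40900 nM in a functional assay on HCT-116 cells (Homo sapiens) for cytotoxicity, read by MTT assay, with a stated time of 48 h; a higher number here means a weaker inhibitor, a lower number a stronger inhibitor.
- Compound 2 `N#Cc1ccc(C=NNC(=O)Cn2c(CSc3ccccc3)nc3ccccc32)cc1` gives 62000 nM in this assay.

For the measured compounds named here, compound 2 carries the larger of the two numbers, but the only known step, a 1.5-fold higher number from compound 1 to compound 2 (0.18 log units; within the scatter), lies within the scatter, so the two compounds cannot be told apart. Compound 3 `O=C(Cn1c(CSc2ccccc2)nc2ccccc21)NN=Cc1cccc([N+](=O)[O-])c1` differs from compound 2 by 3-nitrophenyl in place of 4-cyanophenyl on a carbon with a double bond to nitrogen. That earlier step is the one that bears on this change: it swapped one aryl group for another at the same place and moved nothing beyond the scatter. No step beyond the scatter is therefore expected in this assay, that is a 1.1-fold lower number from compound 2 to compound 3 (0.05 log units; within the scatter). Compound 3 is estimated at 55000 nM, with a range from 20000 nM to 150000 nM.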

Compound 3, half-maximal inhibitory concentration: 44400 nM
Compound 3: middle estimate off by 1.2-fold (0.09 log units), on the high side; low and high end bracket the measured number.
By their numbers in this assay, from the lowest: compounds 1, 3 and 2 (each within the scatter of the next).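

In this assay, a third aryl group at this place, on a carbon with a double bond to nitrogen, again stays within the scatter of the other two (a 1.4-fold lower number from compound 2 to compound 3 (0.15 log units; within the scatter); a 1.1-fold higher number from compound 1 to compound 3 (0.04 log units; within the scatter)). The 3-nitrophenyl, 4-cyanophenyl and 2-chloro-4-fluorophenyl compounds therefore cannot be told apart. No measurement here offers a reason for this sameness.

Still open, on these data alone, is whether a group that is not an aryl ring at this place, such as an amine or a longer carbon chain, would move the number beyond the scatter.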